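This account rests on a few compounds, and the source may have more. Where it says the series, first, only, none or still open, it means among the compounds named here.

Measured in an ADME assay on the whole organism (plasma, Rattus norvegicus) for protein binding, using cassette dosing, at a dose of 1 mg/kg; on this read-out lower numbers stand for a smaller free fraction and higher numbers for a larger free fraction:
- Compound 1 `C[C@@H](Cn1c(=O)[nH]/c(=N\c2ccc(Oc3cncc(F)c3)cc2)n(Cc2ccc(Cl)cc2)c1=O)C(=O)O`: 0.02
- Compound 2 `C[C@@H](Cn1c(=O)[nH]/c(=N\c2ccc(Oc3ccc(F)cn3)cc2)n(Cc2ccc(Cl)cc2)c1=O)C(=O)O`: 0.011

Compound 2, at 0.011, lies within the usual scatter of compound 1. Compound 3 `C[C@@H](Cn1c(=O)[nH]/c(=N\c2ccc(Oc3cnccn3)cc2)n(Cc2ccc(Cl)cc2)c1=O)C(=O)O` carries pyrazin-2-yl in place of 5-fluoropyridin-2-yl on an oxygen on an aromatic ring. For the measured compounds named here, the only measured step, a 1.8-fold lower number from compound 1 to compound 2 (0.26 log units; within the scatter), changes the same place but exchanges a different pair of rings, so it offers only indirect guidance. In this assay, the estimated step is small, a 1.8-fold higher number from compound 2 to compound 3 (0.26 log units; within the scatter), and no clear shift beyond the scatter is expected. For compound 3 the estimate is 0.02, with an expected range of 0.008 to 0.05.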

Compound 3, unbound fraction: 0.018
The estimate for compound 3 lay 1.1-fold (0.05 log units) above the measured number; low and high end bracket the measured number.
By their numbers in this assay, from the lowest: compounds 2, 3 and 1 (each within the scatter of the next).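

Read in this assay, pyrazin-2-yl on this oxygen can be set against both fluorinated rings: a 1.6-fold higher number from compound 2 to compound 3 (0.21 log units; within the scatter) and a 1.1-fold lower number from compound 1 to compound 3 (0.05 log units; within the scatter) both stay within the scatter. A ring with no fluorine and with 2 hetero atoms therefore gives no clear shift in free fraction at this position, something compound 1 and compound 2 alone could not show.

Going by these compounds, whether an amine or a longer alkyl chain in place of the aromatic ring would move the free fraction beyond the scatter remains open. No independent measurement bears on what sets the free fraction in this series.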